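A few compounds are considered here, and "the series" means these few. Any claim that something is new, unique, unknown or untested is made for them only; others in the source may bear on it.

All three measured compounds share one core and differ in the group attached to an amine nitrogen in a ring. In an assay on HEK293 cells for inhibition of Voltage-dependent T-type calcium channel subunit alpha-1G (Homo sapiens), read by patch clamp (a higher number here means a weaker inhibitor, a lower number a stronger inhibitor), compound 1 `CCCc1nc(-c2ccccc2)c(CNCCN2CCN(C(c3ccccc3)c3ccccc3)CC2)o1` gives 7470 nM. Compound 2 `CCCc1nc(-c2ccccc2)c(CNCCCN2CCN(c3cccc(C)c3C)CC2)o1` gives 1780 nM in this assay. Compound 3 `CCCc1nc(-c2ccccc2)c(CNCCN2CCN(c3ccccc3C(F)(F)F)CC2)o1` gives 2100 nM in this assay. Compound 2 and compound 3 give numbers that lie within the usual scatter of each other, so neither can be called the stronger inhibitor; both stand well apart from compound 1, whose number is higher by more than the scatter.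

Compound 4 `CCCc1nc(-c2ccccc2)c(CNCCCN2CCN(c3cccc(Cl)c3)CC2)o1` is not yet measured. It differs from compound 2 in one place: 3-chlorophenyl in place of 2,3-dimethylphenyl on an amine nitrogen in a ring. Both groups are a single six-membered aromatic ring of carbon only, with no hydrogen-bond donors or acceptors, and the chain and the rest of the core are unchanged. Among the compounds with values here, no measured pair shows this exact change, so the size of the step is open. The nearby comparison of compound 2 with compound 3 suggests that swapping one such ring for another moves the number little. The expected step from compound 2 to compound 4 is a 1.4-fold higher number from compound 2 to compound 4 (0.15 log units; within the scatter), a small rise within the scatter. Compound 4 is therefore expected to give about 2500 nM in this assay, with a likely range from 900 nM to 7000 nM.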

Compound 4, half-maximal inhibitory concentration: 1750 nM
Estimate against measurement, compound 4: 1.4-fold (0.15 log units) above, and the stated range covers the measured number.
By their numbers in this assay, from the lowest: compounds 4, 2 and 3 (each within the scatter of the next); then compound 1.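

Within the data shown here, the pair compound 2 and compound 4 is the first in this set that differs in one place only, so it gives the first direct reading of a change on this ring nitrogen. In this assay, putting 3-chlorophenyl in place of 2,3-dimethylphenyl gives a 1.0-fold lower number from compound 2 to compound 4 (0.01 log units; within the scatter), which lies within the scatter, so the two compounds cannot be told apart even though the aromatic ring trades two methyl groups for one chlorine. At this position and with this chain, then, this particular exchange leaves the reading unchanged as far as the assay can tell, although nothing shown explains why.

The compounds shown leave open whether that holds for a plain phenyl ring, for a pyridine ring, which carries a nitrogen in the ring, or for a phenyl ring bearing a methoxy group or a carboxylic acid. No pair differs in the chain alone, so the effect of a shorter or longer chain between the two amine nitrogens cannot be read, and neither can the separate effects of the other changes among these compounds.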